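Side-chain change from compound 2: clearance notes

The compounds below may be only part of what the source reports. "The series", "measured", "known", "first", "only" and "open" are said of these compounds alone.

In an ADME assay on liver for metabolic stability, with Liver microsome (Homo sapiens) as the target, using microsomes and NADPH, with a stated time of 30 min, tested at 0.5 uM (a higher number here means faster removal of the compound, a lower number slower removal), compound 1 (`CN1CCN(CCOc2nn(-c3ccccc3F)c3ccc(F)cc23)C1=O`) gives 1000 mL/min/kg and compound 2 (`O=C1OCCN1CCOc1nn(-c2ccccc2F)c2ccc(F)cc12`) gives 683 mL/min/kg, values within the scatter of each other. The structure of compound 3 (`Fc1ccc2c(c1)c(OCCn1ccnc1)nn2-c1ccccc1F`) differs from compound 2 on the side chain: 1H-imidazol-1-yl in place of 2-oxo-1,3-oxazolidin-3-yl on a saturated chain carbon, two bonds along the chain from an oxygen on an aromatic ring. Within the data shown here, the only measured step at this place, a 1.5-fold lower number from compound 1 to compound 2 (0.17 log units; within the scatter), involves no aromatic group, so it offers limited guidance here. The expected step is a 1.2-fold lower number from compound 2 to compound 3 (0.09 log units; within the scatter), which would stay within the scatter. The estimate for compound 3 is 550 mL/min/kg, with an expected range of 220 mL/min/kg to 1100 mL/min/kg.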

Compound 3, clearance: 150 mL/min/kg
For compound 3 the middle estimate is 3.7-fold (0.56 log units) above the measured one, outside the stated range (below it).
By their numbers in this assay, from the lowest: compound 3; then compounds 2 and 1 (each within the scatter of the next).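

In this assay, this side-chain position proves sensitive to the group it carries: a 4.6-fold lower number from compound 2 to compound 3 (0.66 log units; beyond the scatter) and a 6.7-fold lower number from compound 1 to compound 3 (0.82 log units; beyond the scatter), whereas compound 1 and compound 2, with their non-aromatic rings, lie within the scatter of each other. 1H-imidazol-1-yl thus stands apart from both of those rings, although it has the same hydrogen-bond donor and acceptor counts as 2-oxo-1,3-oxazolidin-3-yl. No measurement here explains the lower number.

Going by these compounds, whether the lower number extends to aromatic rings generally or belongs to 1H-imidazol-1-yl alone remains open. A 1H-pyrazol-1-yl or phenyl group at the same place would separate these two readings.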